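The source may hold more compounds than are shown below. What is called first, only, known or untested is meant among the compounds shown, and "the series" means these compounds.

Compound 1 `COc1ccccc1NC(=O)N[C@@H](C)c1ccccc1` and compound 2 `COc1cccc(NC(=O)N[C@H](C)c2ccccc2)c1` contain the same atoms joined differently; the difference between the two cores is not broken down here. In an ADME assay on the whole organism with Oryza sativa as the target, tested at 1 uM (on this read-out higher numbers stand for a weaker effect at the one concentration tested and lower numbers for a stronger effect), compound 1 gives 99% and compound 2 gives 92%; the two numbers lie within the usual scatter of each other. Compound 3 `CC(=O)c1ccccc1NC(=O)N[C@@H](C)c1ccccc1` arises from compound 1 by one change, acetyl in place of methoxy on an aromatic carbon In this assay compound 3 gives 97%, which means a number 2 percentage points lower from compound 1 to compound 3 (within the scatter). Compound 4 `CC(=O)c1cccc(NC(=O)N[C@H](C)c2ccccc2)c1` has not been measured in this assay. It arises from compound 2 by the same kind of change, acetyl in place of methoxy on an aromatic carbon The two places are not identical: in compound 3 the group sits ortho to a large group, in compound 4 meta to a large group. Going by the values given here, the change occurs only twice among the compounds, so only this one measured step guides expectation. Compound 4 is expected to show a number 2 percentage points lower from compound 2 to compound 4 (within the scatter) because a number 2 percentage points lower from compound 1 to compound 3 (within the scatter). Compound 4 is thus estimated at 90%, with an expected range from 80% to 99%.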

Compound 4, a percentage reported as activity, at one concentration (the size of the read-out at that concentration, not a potency): 88%
Estimate against measurement, compound 4: 2 percentage points above; measured number inside the range.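

In this assay, acetyl in place of methoxy on an aromatic carbon, here meta to a large group, gives a number 4 percentage points lower from compound 2 to compound 4 (within the scatter), and the two measured cases of this change agree: the same change on two cores in this assay, a number 2 percentage points lower (within the scatter) from compound 1 to compound 3 and a number 4 percentage points lower (within the scatter) from compound 2 to compound 4, 2 percentage points apart, within the scatter of two such steps On these two cores, the change therefore carries over without a detectable difference, even though the group does not sit in the same place in compound 3 and compound 4. This does not show that the change has a real effect on either core, as both steps stay within the scatter, and two cores in one assay at a single concentration give no basis for extending the result to other cores.

Only methoxy and acetyl are shown on this aromatic ring, so it remains open whether an amine, a carboxylic acid or a longer chain would produce a step beyond the scatter. Also open, from the compounds shown here alone, is whether the agreement between the two cores would hold at other concentrations, where a step of this change might be large enough to compare.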